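Aryl substitution and minimum effective dose in a mouse model

This account rests on a few compounds, and the source may have more. Where it says the series, first, only, none or still open, it means among the compounds named here.

Measured compounds:
compound 1, `CC1CC(=O)N(CC(=O)N2CCN(c3cccc(Cl)c3)CC2)C1=O`, 100 mg/kg
compound 2, `CC1CC(=O)N(CC(=O)N2CCN(c3ccccc3)CC2)C1=O`, 300 mg/kg

Of the compounds shown here, two sharing one core have been tested in a functional assay on the whole organism (strain CD1) with Mus musculus as the target, with a stated time of 0.5 h; a lower number here means that less compound is needed, a higher number that more compound is needed for the effect. Within the data shown here, compound 2 stands highest of the two numbers; its nearest neighbour is compound 1, and the only step recorded, a 3.0-fold higher number from compound 1 to compound 2 (0.48 log units; beyond the scatter), sets the two apart by more than the scatter. Compound 3, `CC1CC(=O)N(CC(=O)N2CCN(c3cccc(C(F)(F)F)c3)CC2)C1=O`, remains to be measured. It differs from compound 2 in one place: trifluoromethyl in place of hydrogen on an aromatic carbon. Among the measured compounds shown here, the single measured step that bears on this change is a 3.0-fold higher number from compound 1 to compound 2 (0.48 log units; beyond the scatter), which shows that removing a chloro from this aromatic carbon raised the number in this assay by a modest amount beyond the scatter. Putting a trifluoromethyl onto the same carbon is the reverse kind of move, so a downward step in this assay is expected for compound 3, of about the size seen before, a 3.0-fold lower number from compound 2 to compound 3 (0.48 log units; beyond the scatter). On this basis compound 3 is estimated at 100 mg/kg, with a range from 30 mg/kg to 300 mg/kg.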

Compound 3, minimum effective dose: 300 mg/kg
Compound 3: middle estimate off by 3.0-fold (0.48 log units), on the low side; measured number inside the range.
By their numbers in this assay, from the lowest: compound 1; then compounds 2 and 3 (each within the scatter of the next).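

In this assay, the carbon that carries the chloro of compound 1 does not respond to every group in the same way: trifluoromethyl in place of hydrogen gives no change at the digits printed from compound 2 to compound 3 (within the scatter), so the downward step seen with chloro does not carry over to this group. Trifluoromethyl in place of chloro gives a 3.0-fold higher number from compound 1 to compound 3 (0.48 log units; beyond the scatter), which shows that the two groups can be told apart at this carbon and that simply having a group there is not enough to lower the number; among these three compounds, only chloro stands apart from hydrogen beyond the scatter. Nothing is available that bears on why chloro and trifluoromethyl part ways here.

The compounds shown leave open whether the chloro result is particular to that atom or is shared by other small groups on the same carbon, such as fluoro, bromo, methyl or methoxy. They also leave open how an amine or a carboxylic acid would read there, and whether chloro would give a similar step on another carbon of the same aromatic ring.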